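Swapping the amide of compound 3 for an ester

This account rests on a few compounds, and the source may have more. Where it says the series, first, only, none or still open, it means among the compounds named here.

Compound 1 `CCCCCCCCCCCC[C@@H](O)[C@H]1CC[C@H]([C@H](O)CCCCCCCCCCNC(=O)c2ccnn2C)O1`: 100000 nM
Compound 2 `CCCCCCCCCCCC[C@@H](O)[C@H]1CC[C@H]([C@H](O)CCCCCCCCCCN(C)C(=O)c2ccnn2C)O1`: 12000 nM
Compound 3 `CCCCCCCCCCCC[C@@H](O)[C@H]1CC[C@H]([C@H](O)CCCCCCCCCCC(=O)Nc2ccnn2C)O1`: 100000 nM

All three compounds were tested in a functional assay on HCC 2998 cells (Homo sapiens) for inhibition, read by sulforhodamine B assay, with a stated time of 48 h; a higher number here means a weaker inhibitor of growth, a lower number a stronger inhibitor of growth. Compound 3 stands level with compound 1, and the two share the highest number of the three. Compound 2 sits apart from them, with an 8.3-fold higher number from compound 2 to compound 3 (0.92 log units; beyond the scatter).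

Compound 4 `CCCCCCCCCCCC[C@@H](O)[C@H]1CC[C@H]([C@H](O)CCCCCCCCCCOC(=O)c2ccnn2C)O1` has not yet been measured. It differs from compound 3 by ((1-methyl-1H-pyrazol-5-yl)carbonyl)oxy in place of (1-methyl-1H-pyrazol-5-yl)carbamoyl on a saturated chain carbon, ten or more bonds along the chain from an oxygen on a saturated carbon and a saturated ring carbon.

Within the data shown here, two measured steps bear on this change. Turning the amide link around gave no change at the digits printed from compound 1 to compound 3 (within the scatter), so the direction of the link alone showed no effect on the number. Putting methyl on the amide nitrogen gave an 8.3-fold lower number from compound 1 to compound 2 (0.92 log units; beyond the scatter), and compound 4, like compound 2, has no amide hydrogen. That single step is thin support, and an ester is not a methylated amide, so a similar or smaller move towards a lower number is expected.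

The expected change is a 4.0-fold lower number from compound 3 to compound 4 (0.60 log units; beyond the scatter). For compound 4 the estimated value is 25000 nM, within an expected range of 6000 nM to 100000 nM.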

Compound 4, concentration for 50% growth inhibition: 46800 nM
Compound 4: middle estimate off by 1.9-fold (0.27 log units), on the low side; low and high end bracket the measured number.
By their numbers in this assay, from the lowest: compound 2; then compound 4; then compounds 1 and 3 (each within the scatter of the next).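

In this assay, the ester link of compound 4 sits only modestly away from both amides that keep their hydrogen, with a 2.1-fold lower number from compound 3 to compound 4 (0.33 log units; beyond the scatter) and with a 2.1-fold lower number from compound 1 to compound 4 (0.33 log units; beyond the scatter) on the same scale. The loss of the amide hydrogen therefore does not by itself match the methylated amide, as the ester remains short of it, with a 3.9-fold higher number from compound 2 to compound 4 (0.59 log units; beyond the scatter) and beyond the scatter. Nothing measured here explains that gap between the ester and the methylated amide.

The compounds shown do not tell whether methyl on the nitrogen of the (1-methyl-1H-pyrazol-5-yl)carbamoyl group would lower the number as it does in the other amide. They also leave open how a plain ether or a sulfonamide link would read at this place on the chain.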